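The source may report more compounds than this note shows. Statements on the series, on what has been measured and on what is new or still open speak of the compounds shown alone.

Compound 3 `OC[C@H]1OC(n2cnc3c(-c4ccco4)ncnc32)[C@H](O)[C@@H]1O` carries a furan-2-yl group on the shared core and, in a functional assay on CCRF-CEM cells (Homo sapiens) for inhibition (a lower number here means a stronger inhibitor, a higher number a weaker inhibitor), compound 3 gives 600 nM, the lowest of the two numbers recorded. Among the compounds with values here, compound 1 `Cn1cccc1-c1ncnc2c1ncn2C1O[C@H](CO)[C@@H](O)[C@H]1O` gives 2000 nM, and the step of a 3.3-fold lower number from compound 1 to compound 3 (0.52 log units; beyond the scatter) is the only measured change of the aryl group. Compound 2 `Cc1cc(-c2ncnc3c2ncn3C2O[C@H](CO)[C@@H](O)[C@H]2O)on1` gives "not active" (no number reported). Compound 4 `OC[C@H]1OC(n2cnc3c(-c4ccoc4)ncnc32)[C@H](O)[C@@H]1O` has not been measured; it differs from compound 3 in that (furan-3-yl in place of furan-2-yl on an aromatic carbon). Within the data shown here, no measured step exchanges one furan for another, so the precedent bears only loosely: one aryl exchange moved the number modestly. A step of similar or smaller size is expected for compound 4, most likely toward a somewhat higher number. For compound 4 the estimated step is a 1.7-fold higher number from compound 3 to compound 4 (0.22 log units; within the scatter). Compound 4 is therefore expected to give about 1000 nM, within 300 nM to 4000 nM.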

Compound 4, half-maximal inhibitory concentration: 1650 nM
Compound 4: the middle estimate sits 1.7-fold (0.22 log units) below what was measured, and the stated range covers the measured number.
By their numbers in this assay, from the lowest: compound 3; then compounds 4 and 1 (each within the scatter of the next).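

Swapping furan-2-yl for furan-3-yl keeps the same atoms and changes only where the ring is attached to the shared core, yet in this assay this alone gives (a 2.8-fold higher number from compound 3 to compound 4 (0.44 log units; beyond the scatter)). Against the 1-methyl-1H-pyrrol-2-yl group, furan-3-yl gives (a 1.2-fold lower number from compound 1 to compound 4 (0.08 log units; within the scatter)), so the lower number of compound 3 belongs to furan-2-yl and not to furans in general. Nothing available explains why the attachment point matters.

Still open, from the compounds shown here alone, is whether thiophen-2-yl or a plain phenyl ring at this carbon would match furan-2-yl, and how an amine there would compare.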